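This account rests on a few compounds, and the source may have more. Where it says the series, first, only, none or still open, it means among the compounds named here.

Three compounds that share one core and differ in a single group have been tested in a functional assay on HCT-116 cells (Homo sapiens) for inhibition, read by sulforhodamine B assay, with a stated time of 48 h, tested at 50 uM; a lower number here means less inhibition of growth, a higher number more inhibition of growth at the concentration tested. Compound 1 `COc1cc(/C=C/C(=O)/C=C/c2cccc3ccccc23)ccc1OCc1cn(CCOc2cc(=O)oc3ccccc23)nn1`, with naphthalen-1-yl, gives 83%. Compound 2 `COc1cc(/C=C/C(=O)/C=C/c2cc(OC)c(OC)c(OC)c2)ccc1OCc1cn(CCOc2cc(=O)oc3ccccc23)nn1`, with 3,4,5-trimethoxyphenyl, gives 89%. Compound 3 `COc1cc(/C=C/C(=O)/C=C/c2ccco2)ccc1OCc1cn(CCOc2cc(=O)oc3ccccc23)nn1`, with furan-2-yl, gives 72%, the lowest of the three.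

Compound 4 `COc1ccccc1/C=C/C(=O)/C=C/c1ccc(OCc2cn(CCOc3cc(=O)oc4ccccc34)nn2)c(OC)c1` has not yet been measured. It differs from compound 3 in one place: 2-methoxyphenyl in place of furan-2-yl on a double-bonded chain carbon bound to a double-bonded chain carbon. The five-membered aromatic ring therefore gives way to a six-membered aromatic ring of carbon only.

Among the compounds with values here, two measured steps bear on this swap. Each one moves to furan-2-yl from another aromatic group: a number 11 percentage points lower from compound 1 to compound 3 (beyond the scatter) and a number 17 percentage points lower from compound 2 to compound 3 (beyond the scatter). Read in reverse, both suggest that leaving furan-2-yl could bring a modest rise. Neither step involves 2-methoxyphenyl itself, and the step of a number 6 percentage points higher from compound 1 to compound 2 (within the scatter) gives no firm ranking of the two other groups. The expected change is a number 10 percentage points higher from compound 3 to compound 4 (within the scatter). For compound 4 the estimated value is 82%, with an expected range from 71% to 92%.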

Compound 4, percent growth inhibition at one concentration: 70%
For compound 4 the middle estimate is 12 percentage points above the measured one, outside the stated range (below it).
By their numbers in this assay, from the lowest: compounds 4 and 3 (each within the scatter of the next); then compounds 1 and 2 (each within the scatter of the next).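

In this assay the step to 2-methoxyphenyl reads a number 2 percentage points lower from compound 3 to compound 4 (within the scatter) so leaving furan-2-yl does not by itself raise the number, and a six-membered aromatic ring of carbon only is not enough at this position. The other two steps read a number 19 percentage points lower from compound 2 to compound 4 (beyond the scatter) and a number 13 percentage points lower from compound 1 to compound 4 (beyond the scatter) so the position also separates groups built on carbon-only aromatic rings, and a methoxy group on the ring does not settle the outcome either. No measurement shown here gives a reason for these differences.

Still open, as far as these compounds go, is how plain phenyl, with no methoxy group at all, or a phenyl ring carrying an amine would read at this place. A percentage at one concentration also leaves open how these compounds would compare across a range of concentrations.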